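Chloro to Fluoro on the Benzylsulfanyl Arm

The source may report more compounds than this note shows. Statements on the series, on what has been measured and on what is new or still open speak of the compounds shown alone.

Compound 1 `O=C(C1=C(O)C(=O)N(c2nnc(SCc3ccccc3)s2)C1c1ccccc1)c1cc2ccccc2o1`: > 200000 nM in an ADME assay on Vero cells (Chlorocebus sabaeus) for inhibition, read by MTT assay; on this read-out higher numbers stand for lower toxicity in this test and lower numbers for higher toxicity in this test
Compound 2 `O=C(C1=C(O)C(=O)N(c2nnc(SCc3ccc(Cl)cc3)s2)C1c1cccc(O)c1)c1cc2ccccc2o1`: > 200000 nM in this assay

Neither value is a number. For compound 2, this assay reports only a limit, > 200000 nM. Compound 1 sits at the same limit (the limit of > 200000 nM in this assay, at which 2 of the 2 values shown sit). Compound 3 `O=C(C1=C(O)C(=O)N(c2nnc(SCc3ccc(F)cc3)s2)C1c1cccc(O)c1)c1cc2ccccc2o1` differs from compound 2 by fluoro in place of chloro on an aromatic carbon. Going by the values given here, no step between measured compounds exists here, so the step from compound 2 to compound 3 is expected to be none beyond the scatter, a number no higher from compound 2 to compound 3 (the limit leaves the size open), and compound 3 is expected to remain at the limit. Compound 3 is estimated at 200000 nM, in the range 100000 nM to 400000 nM.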

Compound 3, half-maximal cytotoxic concentration: > 200000 nM
Compound 3 gave a limit, no number (the forecaster's own chance of this, stated with the estimate: 85%); the middle value lies on the limit itself.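

Going by these compounds alone, compound 2 and compound 3 both give only a limit, not a number, so no step from one to the other can be read: the limit of > 200000 nM in this assay, at which 3 of the 3 values shown sit. Going by these compounds, whether 4-chlorobenzyl and 4-fluorobenzyl differ at all on this read-out stays open.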